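Trifluoromethyl for Chloro on the Aryl Amide of Compound 3

The compounds below may be only part of what the source reports. "The series", "measured", "known", "first", "only" and "open" are said of these compounds alone.

In a functional assay on MKN-74 cells (Homo sapiens) for antiproliferative activity, with a stated time of 24 h (a higher number here means a weaker inhibitor, a lower number a stronger inhibitor), compound 3 `COc1ccccc1NC(=S)N1CCc2c(sc(NC(=O)c3ccccc3Cl)c2C(N)=O)C1` gives 35200 nM and stands alongside compound 1 `NC(=O)c1c(NC(=O)c2ccccc2Cl)sc2c1CCNC2`, which gives 28700 nM, the two values separated by a 1.2-fold higher number from compound 1 to compound 3 (0.09 log units; within the scatter). Compound 2 `Cc1ccccc1CN1CCc2c(sc(NC(=O)c3ccccc3Cl)c2C(N)=O)C1` reaches only a limit of the assay at > 50000 nM. The other steps show an at least 1.7-fold higher number from compound 1 to compound 2 (0.24 log units; that floor lies within the scatter) and an at least 1.4-fold lower number from compound 2 to compound 3 (0.15 log units; that floor lies within the scatter). Compound 4 `COc1ccccc1NC(=S)N1CCc2c(sc(NC(=O)c3ccccc3C(F)(F)F)c2C(N)=O)C1` differs from compound 3 by trifluoromethyl in place of chloro on an aromatic carbon. Within the data shown here, none of the measured steps touches this place; all three change the group on the amine nitrogen in the ring, so they give no guidance on the aryl amide. Compound 4 is therefore expected to show no step beyond the scatter, a 1.0-fold lower number from compound 3 to compound 4 (0.00 log units; within the scatter). Compound 4 is estimated at 35000 nM, within 12000 nM to 100000 nM.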

Compound 4, half-maximal inhibitory concentration: 34500 nM
Estimate against measurement, compound 4: 1.0-fold (0.01 log units) above; low and high end bracket the measured number.
By their numbers in this assay, from the lowest: compounds 1, 4 and 3 (each within the scatter of the next). At a limit, above all of these: compound 2.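

Among these compounds, this is the first measured change on the aryl amide rather than on the amine nitrogen in the ring. In this assay, trifluoromethyl in place of chloro, ortho to a large group, gives a 1.0-fold lower number from compound 3 to compound 4 (0.01 log units; within the scatter), so this change on an aromatic carbon shows no step beyond the scatter. Nothing measured here offers a reason for this result.

Going by these compounds, whether an amine or a carboxylic acid at this place would move the number stays open. So does whether the same change would read alike on compound 1.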